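Two Chlorines in Place of One Fluorine

A few compounds are considered here, and "the series" means these few. Any claim that something is new, unique, unknown or untested is made for them only; others in the source may bear on it.

Compound 2 `Cc1ccc(NC(=O)NC(=O)c2ccc(OCc3ccccc3F)cc2)cc1-c1nc2ccccc2[nH]1` gives 1830 nM in a functional assay on MNK45 cells (Homo sapiens) for inhibition, read by MTT assay, with a stated time of 48 h; a lower number here means a stronger inhibitor, a higher number a weaker inhibitor. Compound 1 `Cc1ccc(NC(=O)NC(=O)c2ccc(OCc3ccccc3)cc2)cc1-c1nc2ccccc2[nH]1` differs from it by a single atom; in this assay compound 1 gives 35100 nM. Going by the values given here, the step of a 19-fold lower number from compound 1 to compound 2 (1.28 log units; beyond the scatter) is the only measured step, and it leaves compound 2 with the lower of the two numbers, the stronger inhibitor of the pair.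

Compound 3 `Cc1ccc(NC(=O)NC(=O)c2ccc(OCc3cccc(Cl)c3Cl)cc2)cc1-c1nc2ccccc2[nH]1` has not yet been measured. Its change from compound 2 is 2,3-dichlorophenyl in place of 2-fluorophenyl on a saturated chain carbon bound to an oxygen on an aromatic ring. Among the compounds with values here, no measured step involves chlorine, so the expectation rests on the single step of a 19-fold lower number from compound 1 to compound 2 (1.28 log units; beyond the scatter), in which a halogen in place of hydrogen on that aromatic carbon gave a much lower number. Going by these compounds, compound 3 keeps a halogen on that ring and adds a second, so a number close to that of compound 2 is expected, with a wide range because the second halogen and the exchange of fluorine for chlorine are untested here. The expected step is a 1.2-fold lower number from compound 2 to compound 3 (0.09 log units; within the scatter). For compound 3 the estimate in this assay is 1500 nM, from 400 nM to 6000 nM.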

Compound 3, half-maximal inhibitory concentration: 87000 nM
The estimate for compound 3 lay 58-fold (1.76 log units) below the measured number, outside the stated range (above it).
By their numbers in this assay, from the lowest: compound 2; then compound 1; then compound 3.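

In this assay, the halogens on the phenyl ring at this place, on a saturated chain carbon bound to an oxygen on an aromatic ring, turn out to matter a great deal: 2,3-dichlorophenyl in place of 2-fluorophenyl gives a 48-fold higher number from compound 2 to compound 3 (1.68 log units; beyond the scatter) and so removes the whole gain that the single fluorine brought. The change does more than return to the starting point, since 2,3-dichlorophenyl in place of plain phenyl gives a 2.5-fold higher number from compound 1 to compound 3 (0.39 log units; beyond the scatter) and a halogen on this ring can therefore push the number either way, lower with fluorine in compound 2 and higher with two chlorines in compound 3. No measurement at hand accounts for this reversal.

This one step exchanges fluorine for chlorine and also brings in a second halogen, and the compounds shown do not separate these two changes. A phenyl ring carrying one chlorine would speak to the first, one carrying two fluorines to the second, and a ring carrying a methoxy group or an amine would show how this place responds to something other than a halogen.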